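Changing the amide aryl group: expected effect on cytotoxicity

The source may report more compounds than this note shows. Statements on the series, on what has been measured and on what is new or still open speak of the compounds shown alone.

Compound 1 `COC(=O)c1cccc(NC(=O)C2CCCN(C(=O)c3cc(C(F)(F)F)cc(C(F)(F)F)c3)C2)c1`: 0%
Compound 2 `O=C(Nc1cccc(Oc2nccc(C(F)(F)F)c2Cl)c1)C1CCCN(C(=O)c2cc(C(F)(F)F)cc(C(F)(F)F)c2)C1`: 0%

In an ADME assay on PC-3 cells (Homo sapiens) for cytotoxicity, read by WST assay, tested at 100 uM (on this read-out higher numbers stand for more inhibition at the one concentration tested (going by the name of the read-out) and lower numbers for less inhibition), compound 1 gives 0%. Among the measured compounds shown here, compound 2 gives 0%, and the only measured step, no change at the digits printed from compound 1 to compound 2 (within the scatter), shows the two standing level. Compound 3 `O=C(Nc1ccc(Cl)cn1)C1CCCN(C(=O)c2cc(C(F)(F)F)cc(C(F)(F)F)c2)C1` differs from compound 1 by 5-chloropyridin-2-yl in place of 3-(methoxycarbonyl)phenyl on an amide-type nitrogen. For the measured compounds named here, no measured step alters the group on the amide nitrogen, so the expectation rests on both measured compounds showing no inhibition. Compound 3 is therefore expected to show no step beyond the scatter, no change at the digits printed from compound 1 to compound 3 (within the scatter). The estimate for compound 3 is 0%, with a range from 0% to 10%.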

Compound 3, a percentage reported as inhibition, at one concentration (the size of the read-out at that concentration, not a potency): 0%
Beside the measured number, compound 3's estimate shows no gap at the digits printed; the range from low to high includes it.
By their numbers in this assay, from the lowest: compounds 1, 2 and 3 (each within the scatter of the next).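

In this assay, replacing the whole group on the amide-type nitrogen gives no change at the digits printed from compound 1 to compound 3 (within the scatter) for 5-chloropyridin-2-yl in place of 3-(methoxycarbonyl)phenyl. The earlier step changed only a substituent on that aromatic ring, whereas this one exchanges the ring itself, and still no inhibition appears. No measured evidence explains this result.

With all the compounds shown printing the same value, nothing yet shows which groups at this position could produce inhibition. A group carrying an amine or a carboxylic acid remains an open case.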